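Methyl on the pendant phenyl: stability of compound 4

The compounds below may be only part of what the source reports. "The series", "measured", "known", "first", "only" and "open" are said of these compounds alone.

Measured compounds:
compound 1 `C[C@H](Nc1ncnc2[nH]cnc12)c1cc2ccc(F)cn2c(=O)c1-c1ccccc1` — 98%
compound 2 `C[C@H](Nc1nc(N)nc(N)c1C#N)c1cc2ccc(F)cn2c(=O)c1-c1ccccc1` — 87%
compound 3 `C[C@H](Nc1ccnc(N)n1)c1cc2ccc(F)cn2c(=O)c1-c1ccccc1` — "not determined" (no result reported)

The read-out is an ADME assay on microsomes from liver (Homo sapiens), read by LC-MS, using NADPH, with a stated time of 30 min, tested at 1 uM; a higher number here means that more of the compound is left, a lower number that less of the compound is left. For the measured compounds named here, only two numbers are available. Compound 2, with 87%, is the lower of the two; the nearest number belongs to compound 1, and the step of a number 11 percentage points lower from compound 1 to compound 2 (beyond the scatter) lies beyond the scatter. That step exchanges the group on the amine nitrogen and leaves the pendant aromatic ring untouched.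

Compound 4 `Cc1cccc(-c2c([C@H](C)Nc3nc(N)nc(N)c3C#N)cc3ccc(F)cn3c2=O)c1` differs from compound 2 in exactly one place: methyl in place of hydrogen on an aromatic carbon, on an aromatic carbon of a six-membered aromatic ring of carbon only, meta to a large group; cut one bond further out, the change reads phenyl to 3-methylphenyl. Going by the values given here, no measured step touches this ring, so nothing in the data shows how this position answers in this assay. Among the compounds with values here, the one step that exists, from compound 1 to compound 2, concerns a different part of the molecule and does not bear on the change.

The step from compound 2 to compound 4 is therefore expected to be small and not beyond the scatter, a number 5 percentage points lower from compound 2 to compound 4 (within the scatter). For compound 4 the estimated value in this assay is 82%, with a range from 65% to 95%.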

Compound 4, percent of the compound remaining: 89%
Estimate against measurement, compound 4: 7 percentage points below, and the stated range covers the measured number.
By their numbers in this assay, from the lowest: compounds 2, 4 and 1 (each within the scatter of the next, the first and the last beyond it).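

For the compounds shown here, this is the first reading on the pendant ring: in this assay, methyl in place of hydrogen on an aromatic carbon, meta to a large group, gives a number 2 percentage points higher from compound 2 to compound 4 (within the scatter) and so leaves phenyl and 3-methylphenyl indistinguishable. The earlier compounds shown here varied only the group on the amine nitrogen and gave no information about this ring, whereas this pair shows that, with the group on the amine nitrogen of compound 2, this ring position accepts a methyl without a difference beyond the scatter. No evidence shown here accounts for the result.

Going by these compounds, it remains open whether a methyl elsewhere on this ring would read the same, and whether a different group at this place, such as a chlorine, a methoxy, an amine or a carboxylic acid, would leave the reading as undisturbed. It is also open whether the same methyl would give a comparable step with the group on the amine nitrogen of compound 1, since the pair shown covers only one such group.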